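The source may report more compounds than this note shows. Statements on the series, on what has been measured and on what is new or still open speak of the compounds shown alone.

Measured compounds:
compound 1 `CN(C(=O)NC(=O)c1ccc(C(F)(F)F)cc1)c1nc(C(F)(F)F)c(C(=O)N/N=C/c2cccc(C(F)(F)F)c2)s1` – 6.66 ug/mL
compound 2 `CN(C(=O)NC(=O)c1ccc(F)c(F)c1)c1nc(C(F)(F)F)c(C(=O)N/N=C/c2cccc(C(F)(F)F)c2)s1` – 6.52 ug/mL
compound 3 `CN(C(=O)NC(=O)c1ccc([N+](=O)[O-])cc1)c1nc(C(F)(F)F)c(C(=O)N/N=C/c2cccc(C(F)(F)F)c2)s1` – 5.42 ug/mL

In a functional assay on A549 cells (Homo sapiens) for inhibition, read by MTT assay, with a stated time of 72 h (on this read-out higher numbers stand for weaker inhibition and lower numbers for stronger inhibition), all three compounds give numbers that lie within the scatter of one another. For the measured compounds named here, compound 3 has the lowest of the three, but the steps of a 1.2-fold lower number from compound 1 to compound 3 (0.09 log units; within the scatter) and a 1.2-fold lower number from compound 2 to compound 3 (0.08 log units; within the scatter) are both within the scatter, so no compound can be called stronger than another.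

Compound 4 `CN(C(=O)NC(=O)c1ccccc1F)c1nc(C(F)(F)F)c(C(=O)N/N=C/c2cccc(C(F)(F)F)c2)s1` is not yet measured. It differs from compound 3 by 2-fluorophenyl in place of 4-nitrophenyl on a carbonyl carbon. Going by the values given here, the steps that bear on this exchange of the aryl group on that carbonyl are a 1.0-fold lower number from compound 1 to compound 2 (0.01 log units; within the scatter) and a 1.2-fold lower number from compound 2 to compound 3 (0.08 log units; within the scatter), both within the scatter. Three different aryl groups at this position have given the same result, so no step beyond the scatter is expected in this assay: compound 4 is estimated at a 1.2-fold higher number from compound 3 to compound 4 (0.07 log units; within the scatter), giving 6.3 ug/mL with a range of 3.5 ug/mL to 12 ug/mL.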

Compound 4, half-maximal inhibitory concentration: 19.5 ug/mL
Compound 4: middle estimate off by 3.1-fold (0.49 log units), on the low side; measured number outside the range, above it.
By their numbers in this assay, from the lowest: compounds 3, 2 and 1 (each within the scatter of the next); then compound 4.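

In this assay, the aryl group on this carbonyl carbon does matter: 2-fluorophenyl gives a 3.6-fold higher number from compound 3 to compound 4 (0.56 log units; beyond the scatter) and a 3.0-fold higher number from compound 2 to compound 4 (0.48 log units; beyond the scatter) and a 2.9-fold higher number from compound 1 to compound 4 (0.47 log units; beyond the scatter). The earlier agreement among compound 1, compound 2 and compound 3 therefore held for those three aryl groups only, and compound 4 goes against it, with weaker inhibition than any of them. Nothing available here accounts for this loss.

Still open, from the compounds shown here alone, is how a plain phenyl, or a phenyl carrying an amine or a carboxylic acid, would behave at this position. Whether such groups would match compound 4 or the other three compounds cannot be told from these data.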